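Adding a second butylcarbonyl to compound 2

The source may report more compounds than this note shows. Statements on the series, on what has been measured and on what is new or still open speak of the compounds shown alone.

In an ADME assay on HepG2 2.2.15 cells (Homo sapiens) for cytotoxicity, read by MTT assay (a higher number here means that more compound is tolerated, a lower number that less compound is tolerated), compound 1 (`C=C1CC[C@@H]2[C@](C)(COC(=O)CCCC)[C@H](O)CC[C@@]2(C)[C@@H]1C/C=C1\C=COC1=O`) gives 225000 nM. Compound 2 (`C=C1CC[C@@H]2[C@](C)(CO)[C@H](OC(=O)CCCC)CC[C@@]2(C)[C@@H]1C/C=C1\C=COC1=O`) gives 126000 nM, and the two values lie within the usual scatter of each other, so neither stands apart. Compound 3 (`C=C1CC[C@@H]2[C@](C)(COC(=O)CCCC)[C@H](OC(=O)CCCC)CC[C@@]2(C)[C@@H]1C/C=C1\C=COC1=O`) differs from compound 2 by butylcarbonyl in place of hydrogen on an oxygen on a saturated carbon, which reads as hydroxymethyl to ((butylcarbonyl)oxy)methyl. Among the compounds with values here, no measured pair isolates this change. Compound 1 and compound 2 each carry the butylcarbonyl on a different oxygen, while compound 3 carries both. The expectation therefore starts from compound 2 at 126000 nM. The expected 1.1-fold lower number from compound 2 to compound 3 (0.06 log units; within the scatter) is slightly downward and stays within the scatter. For compound 3 the estimated value is 110000 nM, with an expected range of 45000 nM to 260000 nM.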

Compound 3, half-maximal cytotoxic concentration: 757000 nM
Compound 3: middle estimate off by 6.9-fold (0.84 log units), on the low side, outside the stated range (above it).
By their numbers in this assay, from the lowest: compounds 2 and 1 (each within the scatter of the next); then compound 3.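

Within this assay, the butylcarbonyl is not neutral at either oxygen once the other oxygen already carries one: on the hydroxymethyl oxygen it gives a 6.0-fold higher number from compound 2 to compound 3 (0.78 log units; beyond the scatter) and on the remaining hydroxy oxygen it gives a 3.4-fold higher number from compound 1 to compound 3 (0.53 log units; beyond the scatter) as the second ester is added. Both steps point the same way and lie beyond the scatter, so the compound with both hydroxy groups esterified tolerates more than either compound with one free hydroxy, which the two singly esterified compounds could not show on their own. Nothing available explains this rise.

On these data alone, whether the rise depends on the butylcarbonyl itself stays open, since an acetyl group or a longer acyl chain could behave differently. As far as these compounds go, it also remains open whether a non-ester group at these oxygens, such as a methyl ether or an amine-bearing acyl chain, would follow the same direction.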